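Moving a Methyl Along the Sulfonamide Side Chain

The source may report more compounds than this note shows. Statements on the series, on what has been measured and on what is new or still open speak of the compounds shown alone.

Compound 1 `CC(=O)NCc1cncc(N2C(=O)c3ccc(Cl)cc3C2(C)C)c1` gives 59 nM in an assay on cells for inhibition of cytochrome P450 11B2, mitochondrial (Homo sapiens), read by HTRF; a higher number here means a weaker inhibitor, a lower number a stronger inhibitor.
Compound 2 `CCS(=O)(=O)NCc1cncc(N2C(=O)c3ccc(Cl)cc3C2(C)C)c1` gives 92 nM in this assay.

For the measured compounds named here, compound 2 holds the higher of the two numbers, but its only neighbour, compound 1, lies within the scatter: a 1.6-fold higher number from compound 1 to compound 2 (0.19 log units; within the scatter). Compound 3 `C[C@@H](NS(C)(=O)=O)c1cncc(N2C(=O)c3ccc(Cl)cc3C2(C)C)c1` is not yet measured. It keeps every atom of compound 2 but joins them differently: a group of 7 heavy atoms (3 carbon, 1 nitrogen, 2 oxygen, 1 sulfur; no ring) in place of a group of 7 heavy atoms (3 carbon, 1 nitrogen, 2 oxygen, 1 sulfur; no ring), on an aromatic carbon. Going by the values given here, the single measured step, from compound 1 to compound 2, swaps acetyl for ethylsulfonyl on the amine nitrogen and stays within the scatter; no measured step moves a carbon from the sulfonyl side to the chain side or creates a stereocentre, so the record bears only loosely on this change. With nothing pointing in either direction, compound 3 is expected to show a step no larger than the scatter, a 1.0-fold lower number from compound 2 to compound 3 (0.01 log units; within the scatter). The estimate for compound 3 is 90 nM, with a range from 30 nM to 270 nM.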

Compound 3, half-maximal inhibitory concentration: 8 nM
Compound 3: the middle estimate sits 11-fold (1.05 log units) above what was measured; measured number outside the range, below it.
By their numbers in this assay, from the lowest: compound 3; then compounds 1 and 2 (each within the scatter of the next).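

Joining the same atoms differently gives a 12-fold lower number from compound 2 to compound 3 (1.06 log units; beyond the scatter) in this assay and shows that, at this place on the aromatic ring, how the side chain is put together can matter far more than which atoms it contains. The earlier swap of acetyl for ethylsulfonyl stayed within the scatter, whereas the new group, with its 1 defined stereocentre, gives a 7.4-fold lower number from compound 1 to compound 3 (0.87 log units; beyond the scatter) and so also stands clear of the acetyl compound. Nothing available speaks to the cause of this gain.

The compounds shown leave open how the mirror-image form of compound 3 would read, and whether the gain needs the methylsulfonyl end. They also leave open whether a longer chain, such as ethyl in place of the branching methyl, would keep it.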